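Ethyl in place of hydrogen: compound 2 to compound 3

A few compounds are considered here, and "the series" means these few. Any claim that something is new, unique, unknown or untested is made for them only; others in the source may bear on it.

In an ADME assay on CHO cells (Cricetulus griseus) for cytotoxicity, read by LDH release (on this read-out lower numbers stand for stronger inhibition and higher numbers for weaker inhibition), compound 1 `CC(Oc1ccc(Cl)cc1Cl)C(=O)N[C@@H](C)c1ccc(F)cc1` gives 32000 nM as a measured number. Compound 2 `CCC(NC(=O)C(C)Oc1ccc(Cl)cc1Cl)c1ccc(F)cc1` gives > 100000 nM in this assay and this is a limit of the assay, not a number. Compound 3 `CCCCC(NC(=O)C(C)Oc1ccc(Cl)cc1Cl)c1ccc(F)cc1` differs from compound 2 by ethyl in place of hydrogen on a saturated chain carbon, three bonds along the chain from an amide-type nitrogen and an aromatic carbon with the chain going from ethyl to butyl. For the measured compounds named here, no measured step exists, so only a modest move toward lower numbers is expected, possibly none that can be read. The expected change is an at least 1.6-fold lower number from compound 2 to compound 3 (0.22 log units; that floor lies within the scatter) as an estimate. Compound 3 is estimated at 60000 nM with an expected range of 20000 nM to 100000 nM in this assay for now.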

Compound 3, half-maximal inhibitory concentration: > 100000 nM
Compound 3: a limit, no number (the forecaster's own chance of this, stated with the estimate: 50%); middle value at least 1.6-fold (0.22 log units) from the limit.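

No step from compound 2 to compound 3 can be read, because both compounds sit at the same assay limit, which gives no number: the limit of > 100000 nM in this assay, at which 2 of the 3 values shown sit.

Going by these compounds, whether ethyl in place of hydrogen on this saturated chain carbon shifts the read-out at all remains open.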